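Methoxy additions on a fluorinated stilbene series

This account rests on a few compounds, and the source may have more. Where it says the series, first, only, none or still open, it means among the compounds named here.

Compound 1 `Fc1ccccc1/C=C/c1ccccc1` is the parent of the set. In an assay on HepG2 cells for activation of nuclear factor erythroid 2-related factor 2 (Homo sapiens), read by a luciferase reporter, with a stated time of 5 h (on this read-out higher numbers stand for an effect only at larger amounts of compound and lower numbers for an effect already at smaller amounts), compound 1 gives 700 nM. Compound 2 `COc1cccc(/C=C/c2ccccc2F)c1` differs from it by methoxy in place of hydrogen on an aromatic carbon; in this assay compound 2 gives 3800 nM, and the step is a 5.4-fold higher number from compound 1 to compound 2 (0.73 log units; beyond the scatter). Compound 3 `COc1cccc(/C=C/c2cccc(F)c2)c1` carries the fluorine and the methoxy on a different arrangement; in this assay compound 3 gives 2300 nM. The difference between the core of compound 3 and the core of compound 1 is not broken down here. The values of compound 2 and compound 3 lie within the scatter of each other, so no order between them is claimed.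

Compound 4 `COc1ccc(/C=C/c2cccc(F)c2)cc1OC` has not been measured. It differs from compound 3 by methoxy in place of hydrogen on an aromatic carbon. Within the data shown here, this is the same kind of change as the one from compound 1 to compound 2, but not the same: in compound 2 the entering methoxy is meta to a group of 9 heavy atoms, whereas in compound 4 it is ortho to a methoxy group and para to a group of 9 heavy atoms. Among the measured compounds shown here, because the only precedent for a methoxy entering is a 5.4-fold higher number from compound 1 to compound 2 (0.73 log units; beyond the scatter), a move toward a higher number is expected, though the place differs and the size is taken with caution. The step expected in this assay is a 2.6-fold higher number from compound 3 to compound 4 (0.42 log units; beyond the scatter). In this assay compound 4 is estimated at 6000 nM, expected to fall between 2000 nM and 18000 nM.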

Compound 4, half-maximal effective concentration: 9500 nM
The estimate for compound 4 lay 1.6-fold (0.20 log units) below the measured number, within the range that was stated.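

In this assay the entry of a methoxy in place of hydrogen on an aromatic carbon, here ortho to a methoxy group and para to a group of 9 heavy atoms, gives a 4.1-fold higher number from compound 3 to compound 4 (0.62 log units; beyond the scatter). Set beside the earlier step, the change carries from one core to the other in both direction and size, and no difference between the two steps can be claimed: the same change on two cores in this assay, a 5.4-fold higher number (0.73 log units; beyond the scatter) from compound 1 to compound 2 and a 4.1-fold higher number (0.62 log units; beyond the scatter) from compound 3 to compound 4, 1.3-fold (0.12 log units) apart, within the scatter of two such steps. Among these compounds, this agreement rests on only two pairs, with the methoxy entering at a different place in each, so it supports no general rule for other places or other cores and gives no reason why the number rises.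

The compounds shown leave open whether a different group entering at these places, such as an amine, a carboxylic acid or a longer chain like ethoxy or propoxy, would shift the number in the same direction as methoxy or in the opposite one. Also open, as far as these compounds go, is how the methoxy step behaves on a core without the fluorine, and whether a further methoxy on the same ring would add a similar step again.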